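The compounds below may be only part of what the source reports. "The series", "measured", "known", "first", "only" and "open" are said of these compounds alone.

In an assay for inhibition of tyrosine-protein kinase receptor UFO (Homo sapiens), read by 33P incorporation, in the presence of a further agent that is not named here (on this read-out lower numbers stand for stronger inhibition and higher numbers for weaker inhibition), compound 1 `CNc1ncc2c(-c3ccc(N4CCNCC4)nc3)nn(Cc3cn(Cc4ccccc4)nn3)c2n1` gives 400 nM, the lowest of the two numbers in hand. Compound 2 `CNc1ncc2c(-c3ccc(N4CCNCC4)nc3)nn(Cc3cn(-c4ccsc4C(=O)OC)nn3)c2n1` gives 780 nM, and the step of a 2.0-fold higher number from compound 1 to compound 2 (0.29 log units; within the scatter) shows that exchanging the group on the aromatic nitrogen matters little. Compound 3 `CNc1ncc2c(-c3ccc(N4CCNCC4)cc3)nn(Cc3cn(Cc4ccccc4)nn3)c2n1` reaches only the limit > 10000 nM, see (the limit of > 10000 nM in this assay, at which 1 of the 3 values shown sits). The step of an at least 25-fold higher number from compound 1 to compound 3 (1.39 log units; beyond the scatter) marks the exchange of the pyridinyl for the phenyl ring as large. Compound 4 `CCN1CCN(c2ccc(-c3nn(Cc4cn(Cc5ccccc5)nn4)c4nc(NC)ncc34)cn2)CC1` differs from compound 1 by ethyl in place of hydrogen on an amine nitrogen in a ring, piperazin-1-yl becoming 4-ethylpiperazin-1-yl. Among the compounds with values here, neither measured step touches this ring nitrogen, so no direct precedent exists; the one remote exchange was neutral and the one ring exchange large. A small shift is expected, a 1.3-fold higher number from compound 1 to compound 4 (0.10 log units; within the scatter). Compound 4 is estimated at 500 nM, within 150 nM to 2000 nM.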

Compound 4, half-maximal inhibitory concentration: > 10000 nM
Compound 4: a limit, no number; the forecaster's own chance of this, stated with the estimate: 5%; middle value at least 20-fold (1.30 log units) away from the limit.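

In this assay, ethyl in place of hydrogen on the amine nitrogen in the ring gives an at least 25-fold higher number from compound 1 to compound 4 (1.39 log units; beyond the scatter), so this nitrogen is sensitive to a change of only 2 heavy atoms. The entry for compound 4 is a limit, not a number: the limit of > 10000 nM in this assay, at which 2 of the 4 values shown sit. Both large steps now fall within the 6-(piperazin-1-yl)pyridin-3-yl group of compound 1, whereas a 2.0-fold higher number from compound 1 to compound 2 (0.29 log units; within the scatter) lies elsewhere.

The compounds shown leave open whether any substituent on this nitrogen is accepted. A methyl, an acetyl or a 2-hydroxyethyl chain there would test this.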